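Mirror-image pair of cyclopropane sulfonamides tested in mice

The compounds below may be only part of what the source reports. "The series", "measured", "known", "first", "only" and "open" are said of these compounds alone.

Measured compounds:
compound 1, `CC1(C)[C@H](CNc2ccc(F)cc2C(F)(F)F)[C@H]1c1ccc(S(N)(=O)=O)cc1`, 38%
compound 2, `CC1(C)[C@@H](CNc2ccc(F)cc2OC(F)F)[C@@H]1c1ccc(S(N)(=O)=O)cc1`, 16%

In a functional assay on the whole organism with Mus musculus as the target, with stated times of 60 min and 30 min, at a dose of 3 mg/kg by the oral route (a higher number here means more inhibition at the dose given (going by the name of the read-out), a lower number less inhibition), compound 2 gives 16%, the lowest of the two numbers; compound 1 sits higher, by more than the usual scatter. Compound 3, `CC1(C)[C@H](CNc2ccc(F)cc2OC(F)F)[C@H]1c1ccc(S(N)(=O)=O)cc1`, is not yet measured. It differs from compound 2 only in how it is drawn in space: the two compounds have the same atoms and bonds and differ only in configuration as drawn: 2 of 2 stereo elements differ (all stereocentres are inverted: mirror images); a stereocentre at a saturated ring carbon is drawn S in compound 2 and R in compound 3; a stereocentre at a saturated ring carbon is drawn S in compound 2 and R in compound 3. Within the data shown here, no measured pair here shows what such a mirror-image change does, so the step of a number 14 percentage points higher from compound 2 to compound 3 (beyond the scatter) is only an expectation, and could run either way. Compound 3 is estimated at 30%, within 10% to 55%.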

Compound 3, a percentage reported as inhibition, in the whole organism at one dose (the size of the read-out at that dose, not a potency): 8%
Beside the measured number, compound 3's estimate is 22 percentage points above it; measured number below the stated range.
By their numbers in this assay, from the lowest: compounds 3 and 2 (each within the scatter of the next); then compound 1.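

In this assay, inverting both stereocentres gives a number 8 percentage points lower from compound 2 to compound 3 (within the scatter), so this read-out at this dose does not separate the mirror images. This pair isolates a single variable: the fact that compounds 2 and 3 differ only in the configuration as drawn. With the configuration as drawn held the same, difluoromethoxy in place of trifluoromethyl on an aromatic carbon gives a number 30 percentage points lower from compound 1 to compound 3 (beyond the scatter), a step that does stand clear of the scatter.

On these data alone, whether the mirror image of compound 1 would also match it remains open. So does what a nitrile or an amine would give on that aromatic carbon.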